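The compounds below may be only part of what the source reports. "The series", "measured", "known", "first", "only" and "open" are said of these compounds alone.

Measured in a functional assay on KB cells (Homo sapiens) for inhibition, read by sulforhodamine B assay (on this read-out lower numbers stand for stronger inhibition of growth and higher numbers for weaker inhibition of growth), the values are these
compound 1 `Fc1ccc(-c2ccc(-c3ccc(-c4nc5ccccc5[nH]4)cc3)cc2)cc1` gives 41300 nM
compound 2 `Oc1ccc(-c2ccc(-c3ccc(-c4nc5ccccc5[nH]4)cc3)cc2)cc1` gives 41000 nM
compound 3 `Oc1cccc2[nH]c(-c3ccc(-c4ccc(-c5ccc(F)cc5)cc4)cc3)nc12` gives 6920 nM

Compound 3 (6920 nM) has the lowest number of the three. Compound 4 `CN(C)c1ccc(-c2ccc(-c3ccc(-c4nc5c(O)cccc5[nH]4)cc3)cc2)cc1` differs from it in one place (dimethylamino in place of fluoro on an aromatic carbon), with dimethylamino in place of fluoro on an aromatic carbon, para to a large group. The closest measured step also replaces fluoro (a 1.0-fold lower number from compound 1 to compound 2 (0.00 log units; within the scatter)) and stays within the scatter. The other step (a 6.0-fold lower number from compound 1 to compound 3 (0.78 log units; beyond the scatter)) is modest, and its hydroxy remains in compound 4. One such replacement is thin evidence, but no step beyond the scatter is expected in this assay in either direction. The estimated step is small (a 1.0-fold higher number from compound 3 to compound 4 (0.00 log units; within the scatter)). For compound 4 the expected value is 7000 nM (2000 nM to 25000 nM).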

Compound 4, concentration for 50% growth inhibition: 4200 nM
For compound 4 the middle estimate is 1.7-fold (0.22 log units) above the measured one, within the range that was stated.
By their numbers in this assay, from the lowest: compounds 4 and 3 (each within the scatter of the next); then compounds 2 and 1 (each within the scatter of the next).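

In this assay dimethylamino in place of fluoro on an aromatic carbon, para to a large group, gives a 1.6-fold lower number from compound 3 to compound 4 (0.22 log units; within the scatter). Among these compounds, this position, which carries fluoro or hydroxy in the earlier compounds, thus also takes a group of three heavy atoms with one hydrogen-bond acceptor, with no step beyond the scatter while the hydroxy of compound 3 stays in place. Nothing measured here bears on why the number holds at this position. On these data alone, whether a primary amine, a carboxylic acid or a longer chain here would bring a step beyond the scatter remains open. So does whether dimethylamino would behave alike on the core of compound 1, which lacks that hydroxy.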